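The source may report more compounds than this note shows. Statements on the series, on what has been measured and on what is new or still open speak of the compounds shown alone.

Measured compounds:
Compound 1, `COc1cc2ncnc(N3CCc4ccccc43)c2cc1NC(=O)/C=C/CN1CCCC1`: 1510 nM
Compound 2, `CCN(CC)C/C=C/C(=O)Nc1cc2c(N3CCCc4ccccc43)ncnc2cc1OC`: 5310 nM

Within the data shown here, in a functional assay on MCF7 cells (Homo sapiens) for antiproliferative activity, read by MTT assay, with a stated time of 72 h (on this read-out lower numbers stand for stronger inhibition and higher numbers for weaker inhibition), compound 2 gives the highest of the two numbers, and compound 1 gives the lower one, a gap that lies beyond the usual scatter; the two compounds differ in more than one place, so no single step is read from that pair. Compound 3, `COc1cc2ncnc(N3CCCc4ccccc43)c2cc1NC(=O)/C=C/CN1CCCC1`, is not yet measured. It differs from compound 2 by pyrrolidin-1-yl in place of diethylamino on a saturated chain carbon bound to a double-bonded chain carbon, an exchange of one group for another of the same count of heavy atoms and the same count of donors and acceptors. Among the measured compounds shown here, with no measured step of this kind, the expectation is only a modest change, likely within or just beyond the scatter, and if anything toward a lower number. The step of a 1.5-fold lower number from compound 2 to compound 3 (0.18 log units; within the scatter) is the estimated outcome. Compound 3 is thus expected to give about 3500 nM, within a range from 1200 nM to 10000 nM.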

Compound 3, half-maximal inhibitory concentration: 3190 nM
For compound 3 the middle estimate is 1.1-fold (0.04 log units) above the measured one; the range from low to high includes it.
By their numbers in this assay, from the lowest: compound 1; then compounds 3 and 2 (each within the scatter of the next).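

In this assay, pyrrolidin-1-yl in place of diethylamino on a saturated chain carbon bound to a double-bonded chain carbon gives a 1.7-fold lower number from compound 2 to compound 3 (0.22 log units; within the scatter), so this read-out does not separate these two groups at this place. Among these compounds, compound 3 also provides the first single-place comparison with compound 1: 1,2,3,4-tetrahydroquinolin-1-yl in place of 2,3-dihydro-1H-indol-1-yl on an aromatic carbon gives a 2.1-fold higher number from compound 1 to compound 3 (0.32 log units; beyond the scatter), the only one of the two steps beyond the scatter, and only modestly so. Nothing presented explains either step.

It remains open whether piperidin-1-yl, morpholin-4-yl or dimethylamino at the same chain carbon would also stay within the scatter of these compounds. Also open, on these data alone, is whether the ring exchange gives a similar step when diethylamino stands on the chain.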